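This account rests on a few compounds, and the source may have more. Where it says the series, first, only, none or still open, it means among the compounds named here.

Compound 1 `O=C(Nc1cccc([N+](=O)[O-])c1)Nc1nc2ccc(F)cc2s1` gives 0.89 ug/mL. Compound 2 `COc1ccc(NC(=O)Nc2nc3ccc(F)cc3s2)cc1` gives > 10 ug/mL.

In a functional assay on MDA-MB-231 cells (Homo sapiens) for antiproliferative activity, read by sulforhodamine B assay (on this read-out higher numbers stand for weaker inhibition of growth and lower numbers for stronger inhibition of growth), compound 1 gives 0.89 ug/mL. For compound 2, the value > 10 ug/mL is a limit of the assay, not a number. Where compound 2 stands is therefore known only as the limit of > 10 ug/mL in this assay, at which 1 of the 2 values shown sits. Compound 3 `O=C(Nc1ccccc1)Nc1nc2ccc(F)cc2s1` differs from compound 2 by hydrogen in place of methoxy on an aromatic carbon. Among the compounds with values here, no measured pair covers this change. The step of an at least 1.4-fold lower number from compound 2 to compound 3 (0.15 log units; that floor lies within the scatter) is expected to be a modest move toward stronger growth inhibition. Compound 3 is estimated at 7 ug/mL, with a range from 2 ug/mL to 25 ug/mL.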

Compound 3, concentration for 50% growth inhibition: > 10 ug/mL
Compound 3 gave a limit, no number; the forecaster's own chance of this, stated with the estimate: 40%; at least 1.4-fold (0.15 log units) between middle value and limit.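

In this assay, hydrogen in place of nitro on an aromatic carbon gives an at least 11-fold higher number from compound 1 to compound 3 (1.05 log units; beyond the scatter), so the growth inhibition seen with compound 1 is largely lost once the nitro group is gone. The step for hydrogen in place of methoxy cannot be read, because compound 2 and compound 3 both end at a limit of the assay: the limit of > 10 ug/mL in this assay, at which 2 of the 3 values shown sit.

From the compounds shown here alone, whether methoxy and hydrogen differ at all therefore stays open. Also open, going by these compounds, is whether an amine or a nitrile in the place of the nitro group would keep the growth inhibition of compound 1.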